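Swapping the Amine Side Chain on a Sugar-Bearing Core

The source may report more compounds than this note shows. Statements on the series, on what has been measured and on what is new or still open speak of the compounds shown alone.

Of the compounds shown here, three have so far been measured in a functional assay on the whole organism (B cells) with Mus musculus as the target; a lower number here means a smaller maximal response, a higher number a larger maximal response. Compound 1 `C=CCn1c(=O)n(CCCCCCCC)c2nc(N)nc(O)c21` gives 130%. Compound 2 `C=CCn1c(=O)n([C@H]2CO[C@@H](CO)C2)c2nc(N)nc(O)c21` gives 10%. Compound 3 `CN(C)CCCn1c(=O)n(C2OC(CO)[C@@H](O)[C@H]2O)c2nc(N)nc(O)c21` gives 83%. Among these three numbers compound 3 stands second highest: its nearest neighbour is compound 1, whose number lies beyond the scatter above it, and the furthest is compound 2, whose number lies beyond the scatter below it. For the measured compounds named here, no pair of measured compounds differs in just one place, so none of these gaps can be tied to a single structural change.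

Compound 4 `NCC(O)Cn1c(=O)n(C2OC(CO)[C@@H](O)[C@H]2O)c2nc(N)nc(O)c21` has not yet been measured. It differs from compound 3 in one place: 2-amino-1-hydroxyethyl in place of 2-(dimethylamino)ethyl on a saturated chain carbon bound to an aromatic nitrogen. Going by the values given here, nothing among the measured compounds shows what this particular exchange does, so the size of the step has no direct precedent. The step expected in this assay from compound 3 to compound 4 is a number 13 percentage points lower from compound 3 to compound 4 (beyond the scatter), a modest decrease that may well stay within the usual scatter. Compound 4 is therefore estimated to give 70% in this assay, with a range from 40% to 100%.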

Compound 4, largest response reached (reported as maximal response), in percent of the reference or control that the assay uses: 110%
For compound 4 the middle estimate is 40 percentage points below the measured one, outside the stated range (above it).
By their numbers in this assay, from the lowest: compound 2; then compound 3; then compound 4; then compound 1.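

For the compounds shown here, the exchange of 2-(dimethylamino)ethyl for 2-amino-1-hydroxyethyl, on a saturated chain carbon bound to an aromatic nitrogen, gives the first step in this assay that can be tied to a single structural change: a number 27 percentage points higher from compound 3 to compound 4 (beyond the scatter). This shows that the response at this place does not depend on keeping the dimethylamino end of the chain, and that it is sensitive to what sits there, since this one exchange moves the number beyond the usual scatter. The change swaps a group with 0 hydrogen-bond donors for one with 2, but the data give no explanation for the rise in response.

This single step alters two features at once, removing the two methyl groups from the nitrogen and adding a hydroxyl, so the compounds shown cannot say which of the two accounts for the rise. A 3-aminopropyl chain with no hydroxyl, or a 3-(dimethylamino)-2-hydroxypropyl chain that keeps both features of the two groups compared, would pull these apart, while a longer chain or a carboxylic acid in place of the amine would test how much the chain length and the amine itself matter.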